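Swapping the Nitrile for Fluorine on the Pyridine

The source may hold more compounds than are shown below. What is called first, only, known or untested is meant among the compounds shown, and "the series" means these compounds.

Compound 3 `CCC(C)(C)Cc1c[nH]c(CCc2ccc(-c3cccc(C#N)n3)cc2)n1` gives 140 nM in an in vitro assay on CHO cells for displacement of a labelled ligand from Bombesin receptor subtype-3 (Homo sapiens), read by scintillation counting, with a stated time of 2 h (a lower number here means a stronger inhibitor, a higher number a weaker inhibitor), the second highest of three numbers. Compound 2 `CCC(C)(C)Cc1c[nH]c(CCc2ccc(-c3cnccn3)cc2)n1` gives 51 nM in this assay, and the step of a 2.7-fold higher number from compound 2 to compound 3 (0.44 log units; beyond the scatter) lies beyond the scatter. Compound 1 `CCC(C)(C)Cc1c[nH]c(CCc2ccc(-n3ncnn3)cc2)n1` gives 205 nM in this assay, while a 1.5-fold lower number from compound 1 to compound 3 (0.17 log units; within the scatter) stays within the scatter. Compound 4 `CCC(C)(C)Cc1c[nH]c(CCc2ccc(-c3ccc(F)cn3)cc2)n1` differs from compound 3 in one place: 5-fluoropyridin-2-yl in place of 6-cyanopyridin-2-yl on an aromatic carbon. Among the compounds with values here, no measured step makes exactly this exchange, so the small spread among the three numbers, with the modest step of a 2.7-fold higher number from compound 2 to compound 3 (0.44 log units; beyond the scatter) as the largest, is the only guide. Compound 4 is expected at 90 nM, with a range from 40 nM to 200 nM. The expected step of a 1.6-fold lower number from compound 3 to compound 4 (0.19 log units; within the scatter) is modest, toward a lower number, and may stay within the scatter.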

Compound 4, half-maximal inhibitory concentration: 19 nM
Beside the measured number, compound 4's estimate is 4.7-fold (0.68 log units) above it, outside the stated range (below it).
By their numbers in this assay, from the lowest: compound 4; then compound 2; then compounds 3 and 1 (each within the scatter of the next).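

In this assay the 5-fluoropyridin-2-yl group gives the lowest number of the four compounds, with a 7.4-fold lower number from compound 3 to compound 4 (0.87 log units; beyond the scatter) and a 2.7-fold lower number from compound 2 to compound 4 (0.43 log units; beyond the scatter) and an 11-fold lower number from compound 1 to compound 4 (1.03 log units; beyond the scatter). Within the data shown here, the group on this aromatic carbon can therefore shift the number further than the earlier compounds showed. No measurement shown here explains this gain. The names 5-fluoropyridin-2-yl and 6-cyanopyridin-2-yl differ in both the group and its number on the ring, so the effect of fluorine cannot be separated from that of its place. Going by these compounds, whether chlorine, a methoxy group or an amine would do as well also stays open.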